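Pyridin-2-yl substituent swap on the shared core

A few compounds are considered here, and "the series" means these few. Any claim that something is new, unique, unknown or untested is made for them only; others in the source may bear on it.

Among the measured compounds shown here, compound 2 `CCCN(CCC)c1cc(C)nc2c(-c3ncc(Cl)cc3C)c(C)nn12` gives 6.7 nM in an assay on isolated protein for binding affinity to corticotropin-releasing factor receptor 1 (Homo sapiens) (a higher number here means a weaker inhibitor, a lower number a stronger inhibitor), and stands lowest of the two numbers so far; the nearest is compound 1 `CCCN(CCC)c1cc(C)nc2c(-c3ncc(N)cc3C)c(C)nn12`, which gives 85 nM. For the measured compounds named here, the one measured step, a 13-fold lower number from compound 1 to compound 2 (1.10 log units; beyond the scatter), came from the chloro in place of amino on an aromatic carbon and was large. Compound 3 `CCCN(CCC)c1cc(C)nc2c(-c3ncc(C)cc3OC)c(C)nn12` carries 3-methoxy-5-methylpyridin-2-yl in place of 5-chloro-3-methylpyridin-2-yl on an aromatic carbon. Going by the values given here, no measured step exchanges this whole group, so the change is untested here; the step from compound 1 to compound 2 shows only that substituents on this group move the number strongly, and it involves neither methoxy nor methyl. The expectation for compound 3 is therefore a moderately higher number, with wide uncertainty, a step of a 2.2-fold higher number from compound 2 to compound 3 (0.35 log units; beyond the scatter) in this assay. Compound 3 is estimated at 15 nM, within a range from 4 nM to 60 nM.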

Compound 3, inhibition constant: 25 nM
Estimate against measurement, compound 3: 1.7-fold (0.22 log units) below; low and high end bracket the measured number.
By their numbers in this assay, from the lowest: compound 2; then compound 3; then compound 1.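

In this assay the whole pyridin-2-yl group can be exchanged at this position at only a modest cost: 3-methoxy-5-methylpyridin-2-yl in place of 5-chloro-3-methylpyridin-2-yl gives a 3.7-fold higher number from compound 2 to compound 3 (0.57 log units; beyond the scatter) and keeps the number in the same range. The same group still improves on 5-amino-3-methylpyridin-2-yl, with a 3.4-fold lower number from compound 1 to compound 3 (0.53 log units; beyond the scatter) as the step, so compound 3 sits between the two earlier compounds and the chloro pattern is not the only one that serves here. Nothing at hand bears on what lies behind this order.

Which part of the exchange carries the step stays open, as the methoxy, the methyl and the loss of chloro all change together. Also open, from the compounds shown here alone, is how a trifluoromethyl or a nitrile on this pyridin-2-yl group would compare with these three compounds.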